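Removing the group on the triple-bonded carbon of compound 2

This account rests on a few compounds, and the source may have more. Where it says the series, first, only, none or still open, it means among the compounds named here.

Measured so far in a functional assay on MCF7 cells (Homo sapiens) for antiproliferative activity, read by MTT assay, with a stated time of 24 h; on this read-out higher numbers stand for weaker inhibition and lower numbers for stronger inhibition
compound 1 `CCN(CC)CCNC(=O)C1CC(C(CC)(CC)c2ccc(C#CC(C)(C)O)c(C)c2)=CN1CC` gives 3170 nM
compound 2 `CCN(CC)CCNC(=O)C1CC(C(CC)(CC)c2ccc(C#CC(O)C3CCC3)c(C)c2)=CN1CC` gives 1280 nM
compound 3 `CCCC(O)(C#Cc1ccc(C(CC)(CC)C2=CCC(C(=O)NCCN(CC)CC)N2CC)cc1C)CCC` gives 1360 nM

Compound 2 (1280 nM) lies within the usual scatter of compound 3 (1360 nM), so these two cannot be told apart, while the number for compound 1 (3170 nM) is clearly higher. Compound 4 `C#Cc1ccc(C(CC)(CC)C2=CN(CC)C(C(=O)NCCN(CC)CC)C2)cc1C` has not been measured yet. It differs from compound 2 by a single change (a hydrogen atom in place of a group of 6 heavy atoms (5 carbon, 1 oxygen; one four-membered non-aromatic ring of carbon only), on a triple-bonded carbon). Among the measured compounds shown here, one measured step bears on this same carbon, and it is modest (a 2.5-fold lower number from compound 1 to compound 2 (0.39 log units; beyond the scatter)). There, the smaller group goes with the higher number. Taking the group away entirely may therefore push the number up again, although no compound with a bare hydrogen at this place has been measured, so this is a cautious extrapolation from one step. In this assay the expected change, a modest rise, is estimated as a 2.3-fold higher number from compound 2 to compound 4 (0.37 log units; beyond the scatter) and could prove larger or smaller. For compound 4 the estimated value is 3000 nM (expected range 1200 nM to 8000 nM).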

Compound 4, half-maximal inhibitory concentration: > 50000 nM
Compound 4: no number, only a limit (the forecaster's own chance of this, stated with the estimate: 3%); middle value at least 16-fold (1.22 log units) away from the limit.
By their numbers in this assay, from the lowest: compounds 2 and 3 (each within the scatter of the next); then compound 1. At a limit, above all of these: compound 4.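

In this assay compound 4 has no number, only a limit: the limit of > 50000 nM in this assay, at which 1 of the 4 values shown sits.

Both new steps are large, an at least 39-fold higher number from compound 2 to compound 4 (1.59 log units; beyond the scatter) and an at least 15-fold higher number from compound 1 to compound 4 (1.19 log units; beyond the scatter). Until now, this triple-bonded carbon had shown only a modest difference between two oxygen-bearing groups, a 2.5-fold lower number from compound 1 to compound 2 (0.39 log units; beyond the scatter), so the position could have seemed fairly tolerant. Hydrogen in place of either group changes far more than that exchange did, so among these compounds, having a group on this carbon matters much more than which of the two groups it is.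

As far as these compounds go, what remains open is which part of the group counts, the oxygen or the carbon. A tert-butyl group with no oxygen, or an amine in place of the hydroxyl, would help separate the two.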